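Moving the chlorine on the aryl group of compound 1

The source may hold more compounds than are shown below. What is called first, only, known or untested is meant among the compounds shown, and "the series" means these compounds.

Measured compounds:
compound 1, `Oc1ccc(-c2cc(-c3ccccc3)nc(-c3ccccc3Cl)c2)cc1` — 2800 nM
compound 2, `Oc1cccc(-c2cc(-c3ccccc3)nc(-c3ccccc3Cl)c2)c1` — 1480 nM
compound 3, `Oc1ccc(-c2cc(-c3ccccn3)nc(-c3ccccc3Cl)c2)cc1` — "not determined" (no result reported)

In a functional assay on DU-145 cells (Homo sapiens) for cytotoxicity, read by CCK-8 assay and cell counting, with a stated time of 2 days (on this read-out higher numbers stand for weaker inhibition and lower numbers for stronger inhibition), compound 1 gives the highest of the two numbers available; its nearest neighbour is compound 2, which differs by a 1.9-fold lower number from compound 1 to compound 2 (0.28 log units; within the scatter). Compound 3 has no result. Compound 4, `Oc1ccc(-c2cc(-c3ccccc3)nc(-c3ccc(Cl)cc3)c2)cc1`, differs from compound 1 by 4-chlorophenyl in place of 2-chlorophenyl on an aromatic carbon. Among the compounds with values here, no measured step touches this part of the shared core; the only step known concerns the hydroxyl group and lies within the scatter, so it gives no direction. Compound 4 is therefore expected to sit near compound 1 in this assay, with a step of no change at the digits printed from compound 1 to compound 4 (within the scatter). The estimate for compound 4 is 2800 nM, in the range 900 nM to 9000 nM.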

Compound 4, half-maximal inhibitory concentration: 7270 nM
Beside the measured number, compound 4's estimate is 2.6-fold (0.41 log units) below it, and the stated range covers the measured number.
By their numbers in this assay, from the lowest: compounds 2 and 1 (each within the scatter of the next); then compound 4.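

In this assay, the change to 4-chlorophenyl in place of 2-chlorophenyl, next to the ring nitrogen, gives a 2.6-fold higher number from compound 1 to compound 4 (0.41 log units; beyond the scatter). This is the first step shown beyond the scatter, and it is modest: the leaving and entering groups have the same atoms, so this position responds to where the chlorine sits on the aryl group alone. Nothing shown accounts for this step.

On these data alone, it remains open how a 3-chlorophenyl group, or a methoxy or amine in place of the chlorine, would compare at this position. As far as these compounds go, whether the same step appears alongside the 3-hydroxyphenyl group of compound 2 also remains open.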